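The compounds below may be only part of what the source reports. "The series", "measured", "known", "first", "only" and "open" are said of these compounds alone.

Measured compounds:
- Compound 1 `CNc1ncc(-c2ccc(S(C)(=O)=O)cc2)cc1-c1ccc(OC)nc1`: > 100 ug/mL
- Compound 2 `COc1ccc(-c2nc(-c3ccc(S(C)(=O)=O)cc3)cnc2N)cn1`: 12.5 ug/mL
- Compound 3 `COc1ccc(-c2cc(-c3ccc(S(C)(=O)=O)cc3)cnc2NCCCCN)cn1`: > 100 ug/mL

In a physicochemical assay for solubility, measured as kinetic solubility, at pH 2 (on this read-out lower numbers stand for lower solubility and higher numbers for higher solubility), compound 1 gives > 100 ug/mL, which is a limit of the assay rather than a number. Compound 3 also sits at a limit, > 100 ug/mL, so the step that the two limits leave unreadable from compound 1 to compound 3 cannot be read. Going by the values given here, compound 2 gives 12.5 ug/mL, a number, and no step to it from compound 1 is recorded, so the two values can only be set side by side. Among the compounds with values here, the one piece of evidence across the set is the limit of > 100 ug/mL in this assay, at which 2 of the 3 values shown sit.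

Compound 4 `CCOc1ncc(-c2ccc(S(C)(=O)=O)cc2)cc1-c1ccc(OC)nc1` differs from compound 1 in one place: ethoxy in place of methylamino on an aromatic carbon. Within the data shown here, no measured step copies this change, and the only step that is recorded, from compound 1 to compound 3, is unreadable. With the methylamino group gone and an ethoxy group in its place, the expectation is a fall below the limit at which compound 1 stands, though its size cannot be drawn from the measured steps. The estimated step is an at least 5.0-fold lower number from compound 1 to compound 4 (0.69 log units; beyond the scatter). Compound 4 is therefore expected at about 20 ug/mL, within a range from 5 ug/mL to 100 ug/mL.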

Compound 4, solubility: 1.6 ug/mL
Beside the measured number, compound 4's estimate is 13-fold (1.10 log units) above it, outside the stated range (below it).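

In this assay, going by these compounds alone, putting ethoxy in place of methylamino on this aromatic carbon, next to the ring nitrogen, gives an at least 62-fold lower number from compound 1 to compound 4 (1.79 log units; beyond the scatter), the first change at this position whose size can be bounded. Putting the same ethoxy in place of the much longer (4-aminobutyl)amino group gives an at least 62-fold lower number from compound 3 to compound 4 (1.79 log units; beyond the scatter), so on this core both groups joined through nitrogen stand far from ethoxy, which carries no hydrogen-bond donor where each of them does. Each step is only a minimum, because its starting compound sits at a limit rather than at a number: the limit of > 100 ug/mL in this assay, at which 2 of the 4 values shown sit.

From the compounds shown here alone, the step between compound 1 and compound 3 cannot be read, so how methylamino and (4-aminobutyl)amino rank against each other stays open. Going by these compounds, it also stays open where other groups on this carbon, such as a carboxylic acid or a longer ether chain, would fall, and whether the oxygen link, the missing donor or the chain length goes with the drop.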